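The source may hold more compounds than are shown below. What is called first, only, known or untested is meant among the compounds shown, and "the series" means these compounds.

Three compounds share one core and differ only in the group attached to the aromatic ring. Compound 1 `C/C(=N\OCC(=O)O)c1ccc(C(C)(C)C)cc1` carries a tert-butyl group there; in a functional assay on the whole organism for inhibition, with Rattus norvegicus as the target, read by paw edema, with stated times of 1 h and 3 h, at a dose of 50 mg/kg by the oral route (a higher number here means more inhibition at the dose given (going by the name of the read-out), a lower number less inhibition), compound 1 gives < 20%, which is a limit of the assay rather than a number. Compound 2 `C/C(=N\OCC(=O)O)c1ccc(S(C)(=O)=O)cc1` carries a methylsulfonyl group, and in this assay compound 2 gives 20%. Compound 3 `C/C(=N\OCC(=O)O)c1ccc(N)cc1` carries an amino group, and in this assay compound 3 gives 20%. The step of a number no lower from compound 1 to compound 2 (the limit leaves the size open) and the step of a number no lower from compound 1 to compound 3 (the limit leaves the size open) cannot be sized because compound 1 sits at the limit of < 20% in this assay, at which 1 of the 3 values shown sits. For the measured compounds named here, the only fully readable step, no change at the digits printed from compound 2 to compound 3 (within the scatter), shows no movement. Compound 3 therefore stands level with compound 2, and across the whole set the inhibition barely changes with the ring group.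

Compound 4 `C/C(=N\OCC(=O)O)c1ccc([N+](=O)[O-])cc1` is the next variation: nitro in place of amino on an aromatic carbon. Going by the values given here, the steps that bear on this change are the earlier exchanges of the ring group, none of which produced a readable rise or fall, and the one fully measured exchange stayed within the scatter. The expected step of no change at the digits printed from compound 3 to compound 4 (within the scatter) in this assay is therefore one of no size beyond the scatter. Compound 4 is expected to give about 20% in this assay, somewhere between 5% and 35%.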

Compound 4, a percentage reported as inhibition, in the whole organism at one dose (the size of the read-out at that dose, not a potency): < 20%
Compound 4: only a limit was reported; the forecaster's own chance of this, stated with the estimate: 35%; the middle value lies on the limit itself.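

In this assay compound 4 gives < 20%, which is a limit of the assay and not a number. The change from amino to nitro therefore has a direction but no size, as shown by the step of a number no higher from compound 3 to compound 4 (the limit leaves the size open) and the step of a number no higher from compound 2 to compound 4 (the limit leaves the size open), and the step between compound 1 and compound 4 cannot be read either. What is new is that a second group on this aromatic carbon, nitro as well as tert-butyl, ends at the limit rather than at a printed number: the limit of < 20% in this assay, at which 2 of the 4 values shown sit.

The compounds shown leave open how far compound 1 and compound 4 actually lie from compound 2 and compound 3, and whether any real difference separates these four ring groups at all. They also leave open what a chlorine atom, a carboxylic acid or a longer alkyl chain on this aromatic carbon would give in this assay, and whether any group here can lift the inhibition clearly beyond the values seen so far.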